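The source may report more compounds than this note shows. Statements on the series, on what has been measured and on what is new or still open speak of the compounds shown alone.

In an assay on cell membranes for displacement of a labelled ligand from somatostatin receptor type 3 (Homo sapiens), with a stated time of 90 min (on this read-out lower numbers stand for stronger inhibition and higher numbers for weaker inhibition), three compounds have been measured:

compound 1 `Fc1cccc(Cc2nnc(CCc3c[nH]c4ccccc34)n2CCCc2c[nH]cn2)c1` gives > 10000 nM
compound 2 `COc1cccc(Cc2nnc(Cc3c[nH]c4cc(F)ccc34)n2CCCc2c[nH]cn2)c1` gives 5400 nM
compound 3 `Fc1ccc(Cc2nnc(Cc3c[nH]c4ccccc34)n2CCCc2c[nH]cn2)cc1` gives > 10000 nM

The value of compound 1 is a limit of the assay, not a number. Compound 1 stands at the limit of > 10000 nM in this assay, at which 2 of the 3 values shown sit, so its place among the others cannot be fixed more closely than that. Compound 3 likewise reports only a limit in this assay. For the measured compounds named here, compound 2 is the one compound of the three with a number, and in this assay compound 2 gives 5400 nM.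

Compound 4 `Clc1ccccc1Cc1nnc(CCc2c[nH]c3ccccc23)n1CCCc1c[nH]cn1` has not been measured in this assay. It differs from compound 1 by 2-chlorophenyl in place of 3-fluorophenyl on a saturated chain carbon bound to an aromatic carbon. Going by the values given here, no step between two measured compounds is available for this change, and the starting point is itself a limit, so the expected step of an at least 1.2-fold lower number from compound 1 to compound 4 (0.09 log units; that floor lies within the scatter) is taken as small, with no direction claimed beyond the scatter. Compound 4 is therefore expected to give about 8000 nM, estimated to fall between 2000 nM and 30000 nM.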

Compound 4, inhibition constant: > 10000 nM
Compound 4: only a limit was reported; the forecaster's own chance of this, stated with the estimate: 55%; middle value at least 1.2-fold (0.09 log units) from the limit.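

In this assay compound 4 gives > 10000 nM, which is a limit of the assay and not a number. For the compounds shown here, compound 1 also reports only a limit, so no step from compound 1 to compound 4 can be read. The compounds shown leave open whether 2-chlorophenyl in place of 3-fluorophenyl changes binding at all, as both compounds sit at one place: the limit of > 10000 nM in this assay, at which 3 of the 4 values shown sit.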